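Methoxy in Place of Trifluoromethyl on the Shared Core

The source may hold more compounds than are shown below. What is called first, only, known or untested is meant among the compounds shown, and "the series" means these compounds.

Compound 1, `Nc1nc(-c2cc3ccccc3o2)nc2sc(CN3CCC(F)CC3)cc12`, gives 630 nM in an assay on CHO-K1 cells for antagonist activity at adenosine receptor A1 (Homo sapiens), read by a beta-galactosidase reporter, with stated times of 15 min and 6 h; a higher number here means a weaker inhibitor, a lower number a stronger inhibitor.
Compound 2, `N#Cc1cccc(-c2nc(N)c3cc(CN4CCC(F)CC4)sc3n2)c1`, gives 2950 nM in this assay.
Compound 3, `Nc1nc(-c2cccc(C(F)(F)F)c2)nc2sc(CN3CCC(F)CC3)cc12`, gives 3030 nM in this assay.

Compound 3 stands at the highest number of the three, but compound 2 lies within the scatter of it, so the two cannot be told apart; only compound 1 sits clearly lower, beyond the scatter. Compound 4, `COc1cccc(-c2nc(N)c3cc(CN4CCC(F)CC4)sc3n2)c1`, differs from compound 3 by methoxy in place of trifluoromethyl on an aromatic carbon. The step that bears most directly on this change is a 1.0-fold higher number from compound 2 to compound 3 (0.01 log units; within the scatter), an exchange of one small group for another at the same place on the phenyl ring, which stayed within the scatter. The other step, a 4.7-fold higher number from compound 1 to compound 2 (0.67 log units; beyond the scatter), replaced the whole aromatic group and is a poorer guide. On that basis no step beyond the scatter is expected from compound 3 to compound 4, and the estimate is a 1.2-fold lower number from compound 3 to compound 4 (0.08 log units; within the scatter). Compound 4 is therefore expected to give about 2500 nM in this assay, with a range from 800 nM to 8000 nM.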

Compound 4, inhibition constant: 3220 nM
Estimate against measurement, compound 4: 1.3-fold (0.11 log units) below, within the range that was stated.
By their numbers in this assay, from the lowest: compound 1; then compounds 2, 3 and 4 (each within the scatter of the next).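

In this assay the exchange at this place gives a 1.1-fold higher number from compound 3 to compound 4 (0.03 log units; within the scatter), and the comparison with the nitrile gives a 1.1-fold higher number from compound 2 to compound 4 (0.04 log units; within the scatter), so the nitrile, trifluoromethyl and methoxy compounds cannot be told apart. Methoxy carries a hydrogen-bond acceptor where trifluoromethyl carries none, yet this exchange stays within the scatter, whereas replacing the whole aromatic group gives a 5.1-fold higher number from compound 1 to compound 4 (0.71 log units; beyond the scatter), a step beyond it. Nothing at hand accounts for either result.

As far as these compounds go, whether an amine, a carboxylic acid or a longer alkoxy chain on this aromatic carbon would also stay within the scatter of these three compounds remains open. So does whether methoxy, trifluoromethyl and the nitrile would stay as close together on a shared core that carries a group other than the present one.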